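Removing the bromoacrylamide from the chalcone series

The source may report more compounds than this note shows. Statements on the series, on what has been measured and on what is new or still open speak of the compounds shown alone.

Measured so far:
compound 1 `C=C(Br)C(=O)Nc1ccc(C(=O)/C=C/c2ccccc2)cc1` — 960 nM
compound 2 `C=C(Br)C(=O)Nc1ccc(C(=O)/C=C/c2ccc(OC)cc2)cc1` — 310 nM
compound 3 `C=C(Br)C(=O)Nc1ccc(C(=O)/C=C/c2cccc(OC)c2)cc1` — 500 nM

In a functional assay on HeLa cells (Homo sapiens) for antiproliferative activity, with a stated time of 48 h (on this read-out lower numbers stand for stronger inhibition and higher numbers for weaker inhibition), compound 1 gives 960 nM, the highest of the three numbers; compound 3 follows at a 1.9-fold lower number from compound 1 to compound 3 (0.28 log units; within the scatter), and compound 2 stands furthest off at a 3.1-fold lower number from compound 1 to compound 2 (0.49 log units; beyond the scatter). The step from compound 2 to compound 3 is a 1.6-fold higher number from compound 2 to compound 3 (0.21 log units; within the scatter).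

Compound 4 `Nc1ccc(C(=O)/C=C/c2ccccc2)cc1` is not yet measured. It differs from compound 1 by hydrogen in place of (1-bromoethenyl)carbonyl on a nitrogen on an aromatic ring.

All three measured steps concern a methoxy on the distal aromatic ring, and none touches the nitrogen on the aromatic ring where compound 4 departs from compound 1. The measured steps therefore do not bear on this change, and no expectation can be drawn from them for the size or direction of the step in this assay. The estimate below rests on compound 1 alone, which gives 960 nM, and carries a wide range.

For compound 4 the expected value is 6000 nM (range 1000 nM to 40000 nM), which would be an estimated step of a 6.3-fold higher number from compound 1 to compound 4 (0.80 log units; beyond the scatter).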

Compound 4, half-maximal inhibitory concentration: 7700 nM
Estimate against measurement, compound 4: 1.3-fold (0.11 log units) below; low and high end bracket the measured number.
By their numbers in this assay, from the lowest: compounds 2, 3 and 1 (each within the scatter of the next, the first and the last beyond it); then compound 4.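

Among the compounds shown here, the step at this position is the first reading on the nitrogen on the aromatic ring: in this assay, hydrogen in place of (1-bromoethenyl)carbonyl gives an 8.0-fold higher number from compound 1 to compound 4 (0.90 log units; beyond the scatter). The earlier steps shown here changed only a methoxy group, so this shows that the substituent on this nitrogen also affects the read-out, although compound 4, with its free amino group, still gives a finite 7700 nM. Nothing available here explains the step.

For the compounds shown here, the single change removes the bromine, the double bond and the carbonyl together, so their separate contributions remain unresolved; an acetyl group or an unbrominated acryloyl group on the same nitrogen would begin to divide them. As far as these compounds go, whether either methoxy group would shift the number in the same way on the free amine also remains open.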